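Solubility notes on compounds 1 to 4

A few compounds are considered here, and "the series" means these few. Any claim that something is new, unique, unknown or untested is made for them only; others in the source may bear on it.

Measured compounds:
compound 1 `CCC(CC)c1ccc2c(NCCCNCc3cccc(OC)c3O)ccnc2c1`: 4200 nM
compound 2 `COc1cccc(CNCCCNc2ccnc3cc(Oc4cccc(N(C)C)c4)ccc23)c1O`: 14500 nM
compound 3 `COc1cccc(CNCCCNc2ccnc3cc(-c4cccc5ccccc45)ccc23)c1O`: 32000 nM

In a physicochemical assay for solubility, with a stated time of 18 h, at pH 7.4 (a higher number here means a more soluble compound, a lower number a less soluble compound), compound 3 gives the highest of the three numbers. Its nearest neighbour is compound 2, one step below, and the lowest number belongs to compound 1, with the step of a 7.6-fold higher number from compound 1 to compound 3 (0.88 log units; beyond the scatter) separating the two ends. The step of a 2.2-fold higher number from compound 2 to compound 3 (0.34 log units; beyond the scatter) is modest but beyond the scatter, as is a 3.5-fold higher number from compound 1 to compound 2 (0.54 log units; beyond the scatter).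

Compound 4 `COc1ccccc1Oc1ccc2c(NCCCNCc3cccc(OC)c3O)ccnc2c1` is not yet measured. It differs from compound 3 as follows: 2-methoxyphenoxy in place of naphthalen-1-yl on an aromatic carbon. The step that bears most on this change is a 2.2-fold higher number from compound 2 to compound 3 (0.34 log units; beyond the scatter), since compound 2 carries 3-(dimethylamino)phenoxy at the same position and sits below compound 3. Compound 4 with 2-methoxyphenoxy is therefore expected to fall between compound 2 and compound 3, with a modest downward step a 1.8-fold lower number from compound 3 to compound 4 (0.25 log units; within the scatter) from compound 3. The estimate for compound 4 is 18000 nM, with a range of 8000 nM to 40000 nM.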

Compound 4, solubility: 14500 nM
Beside the measured number, compound 4's estimate is 1.2-fold (0.09 log units) above it; the measured number falls inside the stated range.
By their numbers in this assay, from the lowest: compound 1; then compounds 2 and 4 (each within the scatter of the next); then compound 3.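

In this assay, 2-methoxyphenoxy in place of naphthalen-1-yl on this aromatic carbon gives a 2.2-fold lower number from compound 3 to compound 4 (0.34 log units; beyond the scatter), so a second phenoxy group now sits under naphthalen-1-yl. Changing the aryl group on the oxygen from 3-(dimethylamino)phenyl to 2-methoxyphenyl gives no change at the digits printed from compound 2 to compound 4 (within the scatter), so two differently substituted phenoxy groups cannot be told apart here. Against pentan-3-yl, 2-methoxyphenoxy gives a 3.5-fold higher number from compound 1 to compound 4 (0.54 log units; beyond the scatter), which shows that the step seen earlier with 3-(dimethylamino)phenoxy is not confined to that one phenoxy group.

No supporting data bear on why these steps arise. Still open, going by these compounds, is whether the substituent or its place on the phenoxy ring matters at all, which 3-methoxyphenoxy would help separate, and whether a phenoxy group carrying a carboxylic acid would stay level with compound 2 and compound 4.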